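Methyl for vinyl on the fused aromatic ring

The source may hold more compounds than are shown below. What is called first, only, known or untested is meant among the compounds shown, and "the series" means these compounds.

Of the compounds shown here, three have been measured in a functional assay on CHO cells for antagonist activity at Orexin/Hypocretin receptor type 1 (Homo sapiens), read by FLIPR and calcium flux; on this read-out lower numbers stand for stronger inhibition and higher numbers for weaker inhibition. Compound 1 `CCc1nc(C(F)(F)F)c2n1CCN([C@@H](C(=O)NC)c1ccccc1)[C@H]2CCc1ccc(C(F)(F)F)cc1` gives 1070 nM, and compound 2 `CNC(=O)[C@@H](c1ccccc1)N1CCn2c(COC)nc(Cl)c2[C@@H]1CCc1ccc(C(F)(F)F)cc1` gives 1650 nM. Compound 3 `C=Cc1nc(CC)n2c1C(CCc1ccc(C(F)(F)F)cc1)N([C@@H](C(=O)NC)c1ccccc1)CC2` gives 150 nM, the lowest number of the three; its gaps to compound 1 and to compound 2 both lie beyond the usual scatter, so compound 3 stands as the most potent of the measured set.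

Compound 4 `CCc1nc(C)c2n1CCN([C@@H](C(=O)NC)c1ccccc1)C2CCc1ccc(C(F)(F)F)cc1` is compound 3 with methyl in place of vinyl on an aromatic carbon. For the measured compounds named here, no pair of measured compounds differs by this change alone, so the step is not calibrated. A modest loss is expected, a 2.3-fold higher number from compound 3 to compound 4 (0.37 log units; beyond the scatter), because compound 1 with a trifluoromethyl group at the same place gives 1070 nM. Compound 4 is estimated at 350 nM, within 120 nM to 1000 nM.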

Compound 4, half-maximal inhibitory concentration: 10000 nM
Compound 4: the middle estimate sits 29-fold (1.46 log units) below what was measured, outside the stated range (above it).
By their numbers in this assay, from the lowest: compound 3; then compounds 1 and 2 (each within the scatter of the next); then compound 4.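

For the compounds shown here, the single change on this aromatic carbon, methyl in place of vinyl, gives a 67-fold higher number from compound 3 to compound 4 (1.82 log units; beyond the scatter) in this assay, so the group held here strongly affects the read-out. Compound 3 and compound 4 differ only by the vinyl's extra carbon and its double bond outside aromatic rings, and that small difference carries the whole step. Nothing available explains its size.

On these data alone, whether the double bond or the chain length counts remains open. A propyl chain, a nitrile or an amine at this carbon would help separate the two.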